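Benzamide anilide series: pyridin-2-yl extension of compound 1

This account rests on a few compounds, and the source may have more. Where it says the series, first, only, none or still open, it means among the compounds named here.

Compound 1 `Nc1ccccc1NC(=O)c1ccc(Cn2cnc3c(Nc4ccccc4)nc(Cl)nc32)cc1` is the reference point of this set. Going by the values given here, in a functional assay on NCI-H460 cells (Homo sapiens) for antiproliferative activity, read by CCK-8 assay, with a stated time of 72 h, tested at 8 uM (on this read-out lower numbers stand for a weaker effect and higher numbers for a stronger effect at the one concentration tested), compound 1 gives 77.8%, the higher of the two numbers measured so far. Among the compounds with values here, compound 2 `Cc1ccc(Nc2nc(Cl)nc3c2ncn3Cc2ccc(/C=C/C(=O)Nc3ccccc3N)cc2)cc1` differs from compound 1 in more than one place, so no single step links the two. In this assay compound 2 gives 51.3%, a gap beyond the usual scatter, which leaves compound 1 standing highest.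

Compound 3 `Nc1ccccc1NC(=O)c1ccc(Cn2cnc3c(Nc4ccc(-c5ccccn5)cc4)nc(Cl)nc32)cc1` has not yet been measured. Its difference from compound 1 is pyridin-2-yl in place of hydrogen on an aromatic carbon; the entering group sits on an aromatic carbon of a six-membered aromatic ring of carbon only, para to a large group. Within the data shown here, no measured pair isolates a change of this kind, so nothing in the data anchors its direction. The step from compound 1 to compound 3 is expected to be a number 7.8 percentage points lower from compound 1 to compound 3 (within the scatter), small and likely within the scatter. Compound 3 is therefore estimated at 70%, with a range from 45% to 90%.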

Compound 3, a percentage reported as inhibition, at one concentration (the size of the read-out at that concentration, not a potency): 30.8%
Compound 3: middle estimate off by 39.2 percentage points, on the high side, and the stated range ends above it.
By their numbers in this assay, from the lowest: compound 3; then compound 2; then compound 1.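

In this assay, the aromatic carbon para to a large group proves sensitive to substitution: pyridin-2-yl in place of hydrogen gives a number 47 percentage points lower from compound 1 to compound 3 (beyond the scatter). Going by these compounds alone, this is the first single-place step in the set, and it shows that the extension from phenyl to 4-(pyridin-2-yl)phenyl is not neutral at the one concentration tested. Nothing available explains the loss.

A single step cannot separate the presence of a second ring at this carbon from the ring nitrogen of pyridin-2-yl, so an unsubstituted phenyl in the same place would be the informative comparison. On these data alone, whether a small group such as fluorine or methoxy on this carbon keeps the level of compound 1 also remains open.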